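A few compounds are considered here, and "the series" means these few. Any claim that something is new, unique, unknown or untested is made for them only; others in the source may bear on it.

The shared core of compound 1 `Cc1ccc(-c2cn(C/C=C3\OC(=O)C(OCc4ccccc4)=C3OCc3ccccc3)nn2)cc1` carries a 4-methylphenyl group on a five-membered aromatic ring with three nitrogen atoms. In a functional assay on HepG2 cells (Homo sapiens) for antiproliferative activity, read by MTT assay, with a stated time of 72 h (a lower number here means a stronger inhibitor, a higher number a weaker inhibitor), compound 1 reaches only a limit, > 100000 nM. Compound 2 `O=C1O/C(=C\Cn2cc(-c3cc(F)cc(F)c3)nn2)C(OCc2ccccc2)=C1OCc1ccccc1` carries a 3,5-difluorophenyl group in its place. In this assay compound 2 again gives only a limit, > 100000 nM. The step that the two limits leave unreadable from compound 1 to compound 2 therefore cannot be read. Compound 3 `COc1ccc(-c2cn(C/C=C3\OC(=O)C(OCc4ccccc4)=C3OCc3ccccc3)nn2)cc1` is the next member of the set: 4-methoxyphenyl in place of 3,5-difluorophenyl on an aromatic carbon. Within the data shown here, no measured step can be brought to bear on this change, since both values known so far sit at the limit of > 100000 nM in this assay, at which 2 of the 2 values shown sit. Compound 3 is expected to stay at that same limit, so the estimated step of a number no higher from compound 2 to compound 3 (the limit leaves the size open) is none beyond the scatter. The estimate for compound 3 in this assay is 100000 nM, with a range from 30000 nM to 300000 nM.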

Compound 3, half-maximal inhibitory concentration: > 100000 nM
Compound 3: only a limit was reported; the forecaster's own chance of this, stated with the estimate: 80%; the middle value lies on the limit itself.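

In this assay, among these compounds, compound 3, like compound 1 and compound 2, gives only a limit, so no step among the three can be read. The compounds shown leave open whether the 4-methylphenyl, 3,5-difluorophenyl and 4-methoxyphenyl groups differ at all, and what change would give a readable value.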